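Aryl-bromo analogue of the aminoalkyl-linked benzamide series

The source may hold more compounds than are shown below. What is called first, only, known or untested is meant among the compounds shown, and "the series" means these compounds.

Compound 1 `COc1ccc(NC(=O)CNCCCC(=O)Nc2ccccc2N)cc1` gives 8600 nM in a functional assay on HCT-116 cells (Homo sapiens) for inhibition, read by MTT assay, with a stated time of 2 days; a lower number here means a stronger inhibitor of growth, a higher number a weaker inhibitor of growth.
Compound 2 `Nc1ccccc1NC(=O)c1ccc(NCC(=O)Nc2ccc([N+](=O)[O-])cc2)cc1` gives 600 nM in this assay.
Compound 3 `Nc1ccccc1NC(=O)c1ccc(NCC(=O)Nc2ccc(Cl)cc2)cc1` gives 4200 nM in this assay.

Compound 1 gives the highest number of the three; compound 3 sits nearest and compound 2 furthest, both beyond the scatter. Compound 4 `Nc1ccccc1NC(=O)CCCNCC(=O)Nc1ccc(Br)cc1` differs from compound 1 by bromo in place of methoxy on an aromatic carbon. Among the measured compounds shown here, the only measured step touching a halogen on the terminal ring is a 7.0-fold higher number from compound 2 to compound 3 (0.85 log units; beyond the scatter), but there the halogen replaced a nitro on a different core, so it bears on the present change only loosely; no step from methoxy to a halogen is known. The expected step from compound 1 to compound 4 in this assay is therefore small, a 1.2-fold lower number from compound 1 to compound 4 (0.09 log units; within the scatter), in no firm direction. Compound 4 is estimated at 7000 nM, within 3000 nM to 18000 nM.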

Compound 4, concentration for 50% growth inhibition: 7700 nM
Estimate against measurement, compound 4: 1.1-fold (0.04 log units) below; measured number inside the range.
By their numbers in this assay, from the lowest: compound 2; then compounds 3, 4 and 1 (each within the scatter of the next, the first and the last beyond it).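

In this assay the change from 4-methoxyphenyl to 4-bromophenyl on the shared core is a 1.1-fold lower number from compound 1 to compound 4 (0.05 log units; within the scatter), so at this position the two groups cannot be told apart by growth inhibition. The nitro-to-chloro change on the other core, a 7.0-fold higher number from compound 2 to compound 3 (0.85 log units; beyond the scatter), lies beyond the scatter, so a change on this ring need not register; the two cores differ, so the comparison is loose. No measurement at hand explains the flat step.

From the compounds shown here alone, whether a nitro group on this core would lower the number remains open. So does the effect of an amine or a carboxylic acid at this position.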